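The compounds below may be only part of what the source reports. "The series", "measured", "known", "first", "only" and "open" are said of these compounds alone.

Measured in a functional assay on FM3A cells (Mus musculus) for inhibition; on this read-out lower numbers stand for stronger inhibition and higher numbers for weaker inhibition:
- Compound 1 `O=C1O/C(=C\Cn2cc(C(F)(F)F)c(=O)[nH]c2=O)C(OCc2ccccc2)=C1OCc1ccccc1`: 3600 nM
- Compound 2 `O=C1O/C(=C\Cn2cc(Br)c(=O)[nH]c2=O)C(OCc2ccccc2)=C1OCc1ccccc1`: 17100 nM

Of these two, compound 2 holds the higher number, at 17100 nM, so it is the weaker inhibitor. Compound 3 `O=C1O/C(=C\Cn2cc(F)c(=O)[nH]c2=O)C(OCc2ccccc2)=C1OCc1ccccc1` has not yet been measured. It departs from compound 2 by one change, (fluoro in place of bromo on an aromatic carbon), which places fluoro in place of bromo on an aromatic carbon. Among the measured compounds shown here, only one measured step bears on this, and it is also a single swap on that carbon: a 4.8-fold higher number from compound 1 to compound 2 (0.68 log units; beyond the scatter), a modest step beyond the scatter. For the measured compounds named here, no measured compound carries fluoro, so the direction remains uncertain. Compound 2 sits at the high end of this small set, so a modest step of similar size towards a lower number is expected in this assay. The expected change is a 5.7-fold lower number from compound 2 to compound 3 (0.76 log units; beyond the scatter). For compound 3, the estimate is 3000 nM, with an expected range of 400 nM to 17000 nM.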

Compound 3, half-maximal inhibitory concentration: 3400 nM
Estimate against measurement, compound 3: 1.1-fold (0.05 log units) below; low and high end bracket the measured number.
By their numbers in this assay, from the lowest: compounds 3 and 1 (each within the scatter of the next); then compound 2.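

In this assay, fluoro in place of bromo on this aromatic carbon gives a 5.0-fold lower number from compound 2 to compound 3 (0.70 log units; beyond the scatter), so the earlier step from trifluoromethyl to bromo is now matched by a step of similar size from the other side. Fluoro in place of trifluoromethyl gives a 1.1-fold lower number from compound 1 to compound 3 (0.02 log units; within the scatter), so these two groups cannot be told apart at this position, even though one is a single atom and the other is not. Among the three compounds, bromo alone stands apart, and the change at this carbon does not follow the size of the group in any simple way.

Going by these compounds, whether chloro, methyl, an amine or a carboxylic acid on this carbon would fall with bromo or with fluoro and trifluoromethyl remains open. Nothing available here accounts for the gap between bromo and the other two groups.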